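The source may report more compounds than this note shows. Statements on the series, on what has been measured and on what is new or still open speak of the compounds shown alone.

Measured in a functional assay on MCF7 cells (Homo sapiens) for cytotoxicity, read by sulforhodamine B assay, with a stated time of 48 h; a lower number here means a stronger inhibitor of growth, a higher number a weaker inhibitor of growth:
- compound 1 `Cc1nn(-c2ccccc2)c(Oc2ccc(-c3nc4cc([N+](=O)[O-])ccc4[nH]3)cc2)c1/C=N/NC(N)=S` gives 9200 nM
- compound 2 `Cc1nn(-c2ccccc2)c(Sc2ccc(-c3nc4cc([N+](=O)[O-])ccc4[nH]3)cc2)c1/C=N/NC(N)=O` gives 16600 nM
- compound 3 `Cc1nn(-c2ccccc2)c(Sc2ccc(-c3nc4cc(C(=O)O)ccc4[nH]3)cc2)c1/C=N/NC(N)=O` gives 13600 nM

With compound 3 at 13600 nM as its value, the starting point sits among the other two, and its number lies within the usual scatter of both compound 1 and compound 2. In practice, these measurements do not separate compound 3 from either neighbour.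

The next compound is compound 4 `Cc1nn(-c2ccccc2)c(Sc2ccc(-c3nc4cc(C(N)=O)ccc4[nH]3)cc2)c1/C=N/NC(N)=O`, not yet measured. The change is small: amino in place of hydroxy on a carbonyl carbon describes amino in place of hydroxy on a carbonyl carbon, which turns carboxy into carbamoyl.

For the measured compounds named here, no measured compound carries carbamoyl, so the size of this exact change is unknown. Going by the values given here, the nearest evidence is the one measured step at this group, a 1.2-fold lower number from compound 2 to compound 3 (0.09 log units; within the scatter) with carboxy in place of nitro on an aromatic carbon. Compound 1 differs from compound 3 in more than one place, so it offers no single-change comparison.

Since swapping this group has so far moved this assay very little, no step beyond the scatter is expected here. The expected step is a 1.1-fold lower number from compound 3 to compound 4 (0.04 log units; within the scatter) and it is only an estimate. For compound 4 the estimated value is 12500 nM with an expected range from 6000 nM to 25000 nM as its likely span.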

Compound 4, concentration for 50% growth inhibition: 14900 nM
Compound 4: middle estimate off by 1.2-fold (0.08 log units), on the low side; low and high end bracket the measured number.
By their numbers in this assay, from the lowest: compounds 1, 3, 4 and 2 (each within the scatter of the next).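

In this assay, for the compounds shown here, exchanging hydroxy for amino on the carbonyl carbon, which turns carboxy into carbamoyl, gives a 1.1-fold higher number from compound 3 to compound 4 (0.04 log units; within the scatter); this is the first test of a change within the group on this position, rather than the replacement of the whole group. Carbamoyl in place of nitro on the aromatic carbon gives a 1.1-fold lower number from compound 2 to compound 4 (0.05 log units; within the scatter), so with nitro, carboxy and carbamoyl, compound 2, compound 3 and compound 4 cannot be told apart in this assay, and this position has now held three different groups without a step beyond the scatter. Nothing available explains why these three groups read alike.

The compounds shown leave open whether any group at this position can move the number beyond the scatter, for instance an amine or a carbamoyl group carrying a longer chain on its nitrogen. They also leave open whether the same insensitivity would hold on the core of compound 1, which differs from the others in more than one place.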